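Swapping Fluoro for Nitro on a Biaryl Amide Acid

This account rests on a few compounds, and the source may have more. Where it says the series, first, only, none or still open, it means among the compounds named here.

Three compounds share one core and differ only in the group on the outer phenyl ring. Compound 1 `CC(C)N(Cc1cccc(OCCCCCC(=O)O)c1)C(=O)c1ccc(-c2cccc(O)c2)cc1` carries a hydroxy group there. In an ADME assay on Raji cells (Homo sapiens) for cytotoxicity, read by CellTiter-Glo and resazurin assay, with a stated time of 72 h (a higher number here means that more compound is needed for the effect, a lower number that less compound is needed), compound 1 gives > 26000 nM, which is a limit of the assay and not a number. Compound 2 `COc1cc(F)cc(-c2ccc(C(=O)N(Cc3cccc(OCCCCCC(=O)O)c3)C(C)C)cc2)c1` carries a 3-fluoro-5-methoxyphenyl instead, and in this assay compound 2 also gives the limit > 26000 nM. Compound 3 `CC(C)N(Cc1cccc(OCCCCCC(=O)O)c1)C(=O)c1ccc(-c2cccc(F)c2)cc1` carries fluoro, and in this assay compound 3 gives the limit > 26000 nM. Because the limit of > 26000 nM in this assay, at which 3 of the 3 values shown sit, the steps a step that the two limits leave unreadable from compound 1 to compound 2, a step that the two limits leave unreadable from compound 1 to compound 3 and a step that the two limits leave unreadable from compound 2 to compound 3 cannot be sized; compound 3 therefore stands where every measured compound stands, at the limit.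

Compound 4 `CC(C)N(Cc1cccc(OCCCCCC(=O)O)c1)C(=O)c1ccc(-c2cccc([N+](=O)[O-])c2)cc1` differs from compound 3 by nitro in place of fluoro on an aromatic carbon. Among the compounds with values here, the steps that bear on this change are all unreadable, so no step beyond the scatter is expected in this assay, and the step from compound 3 to compound 4 is estimated as a step that the limit leaves unreadable from compound 3 to compound 4. Compound 4 is therefore expected to give 30000 nM, with a range from 12000 nM to 80000 nM, most likely reported again only as a limit.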

Compound 4, half-maximal effective concentration: > 26000 nM
Compound 4 gave a limit, no number; the forecaster's own chance of this, stated with the estimate: 80%; the middle value lies beyond the limit too.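

No step between compound 4 and compounds 1, 2 and 3 can be read, because each value is a limit and not a number: the limit of > 26000 nM in this assay, at which 4 of the 4 values shown sit.

The compounds shown leave open whether the outer-ring groups differ at all in this assay, and at what concentration any of them reaches the half-maximal effect.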